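Methanesulfonamido for Methyl on an Amide Pair

A few compounds are considered here, and "the series" means these few. Any claim that something is new, unique, unknown or untested is made for them only; others in the source may bear on it.

compound 1 `O=C(Nc1ccc(Cl)cn1)C1CCCN(C(=O)c2cc(C(F)(F)F)cc(C(F)(F)F)c2)C1`: 0%
compound 2 `Cc1cccc(C(=O)N2CCCC(C(=O)Nc3ccc(Cl)cc3)C2)c1`: 0%

In an ADME assay on PC-3 cells (Homo sapiens) for cytotoxicity, read by WST assay, tested at 100 uM (a lower number here means less inhibition, a higher number more inhibition at the concentration tested (going by the name of the read-out)), compound 1 gives 0%. In this assay compound 2 gives 0%, level with compound 1 at the digits reported, a difference within the scatter. Compound 3 `CS(=O)(=O)Nc1cccc(C(=O)N2CCCC(C(=O)Nc3ccc(Cl)cc3)C2)c1` has not yet been measured. It differs from compound 2 by methanesulfonamido in place of methyl on an aromatic carbon. For the measured compounds named here, no step between measured compounds speaks to this change, and both measured compounds sit at the bottom of the scale, so no movement beyond the scatter is expected. The expected step is a number 2 percentage points higher from compound 2 to compound 3 (within the scatter). In this assay compound 3 is expected to give 2%, in the range 0% to 15%.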

Compound 3, a percentage reported as inhibition, at one concentration (the size of the read-out at that concentration, not a potency): 3%
Estimate against measurement, compound 3: 1 percentage points below; the measured number falls inside the stated range.
By their numbers in this assay, from the lowest: compounds 1, 2 and 3 (each within the scatter of the next).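

Methanesulfonamido in place of methyl on an aromatic carbon gives a number 3 percentage points higher from compound 2 to compound 3 (within the scatter) in this assay. For the compounds shown here, this is the first single change that can be read here: at this place, meta to a large group, a swap that brings in a hydrogen-bond donor and hydrogen-bond acceptors does not move the read-out beyond the scatter. No measurement on hand offers an explanation for this result. Still open, as far as these compounds go, is whether an amine or a carboxylic acid at this place would also stay within the scatter.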